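Propyl-to-ethyl step carried onto the benzylamine analogue

This account rests on a few compounds, and the source may have more. Where it says the series, first, only, none or still open, it means among the compounds named here.

Measured so far in an assay on cells for displacement of a labelled ligand from corticotropin-releasing factor receptor 1 (Homo sapiens), with a stated time of 100 min; a higher number here means a weaker inhibitor, a lower number a stronger inhibitor:
compound 1 `CCCN(Cc1c(C(F)(F)F)nc2n(-c3c(C)cc(C)cc3C)c(Cl)cn12)CC1CCC1` gives 5.3 nM
compound 2 `CCN(Cc1c(C(F)(F)F)nc2n(-c3c(C)cc(C)cc3C)c(Cl)cn12)CC1CCC1` gives 16 nM
compound 3 `CCCN(Cc1ccccc1)Cc1c(C(F)(F)F)nc2n(-c3c(C)cc(C)cc3C)c(Cl)cn12` gives 170 nM

Compound 3 stands furthest from compound 1, with a 32-fold higher number from compound 1 to compound 3 (1.51 log units; beyond the scatter); the core difference between them is phenyl in place of cyclobutyl on a saturated chain carbon bound to an amine nitrogen. From compound 2 the gap is an 11-fold higher number from compound 2 to compound 3 (1.03 log units; beyond the scatter). Compound 4 `CCN(Cc1ccccc1)Cc1c(C(F)(F)F)nc2n(-c3c(C)cc(C)cc3C)c(Cl)cn12` is not yet measured in this assay.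

The change from compound 3 to compound 4 is hydrogen in place of methyl on a saturated chain carbon, two bonds along the chain from an amine nitrogen. The same change stands between compound 1 and compound 2, (hydrogen in place of methyl on a saturated chain carbon, two bonds along the chain from an amine nitrogen), where it gave a 3.0-fold higher number from compound 1 to compound 2 (0.48 log units; beyond the scatter). The place is described in the same words on both pairs, so it is the same change, only carried onto the core of compound 3. Among the compounds with values here, compound 4 is therefore expected to show a step of about a 2.9-fold higher number from compound 3 to compound 4 (0.47 log units; beyond the scatter) in this assay, resting on the single earlier instance a 3.0-fold higher number from compound 1 to compound 2 (0.48 log units; beyond the scatter). The estimate for compound 4 in this assay is 500 nM, expected within 250 nM to 1100 nM.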

Compound 4, inhibition constant: 350 nM
Beside the measured number, compound 4's estimate is 1.4-fold (0.15 log units) above it; low and high end bracket the measured number.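

In this assay, the new step for propyl to ethyl is a 2.1-fold higher number from compound 3 to compound 4 (0.31 log units; beyond the scatter), and it agrees with the earlier one: the same change on two cores in this assay, a 3.0-fold higher number (0.48 log units; beyond the scatter) from compound 1 to compound 2 and a 2.1-fold higher number (0.31 log units; beyond the scatter) from compound 3 to compound 4, 1.5-fold (0.17 log units) apart, within the scatter of two such steps. Phenyl in place of cyclobutyl also holds its size on the ethyl compounds, at a 22-fold higher number from compound 2 to compound 4 (1.34 log units; beyond the scatter), and both changes together give a 66-fold higher number from compound 1 to compound 4 (1.82 log units; beyond the scatter): the same change on two cores in this assay, a 32-fold higher number (1.51 log units; beyond the scatter) from compound 1 to compound 3 and a 22-fold higher number (1.34 log units; beyond the scatter) from compound 2 to compound 4, 1.5-fold (0.17 log units) apart, within the scatter of two such steps. Within the data shown here, this shows that the two changes carry over between these cores, but with only two pairs each, it does not show that they would carry onto any other core or why the steps agree.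

From the compounds shown here alone, whether a longer chain such as butyl in place of propyl extends the step remains open. So does whether cyclopentyl or pyridyl in place of cyclobutyl gives a step of like size.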